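Chlorophenyl to Hydroxyphenyl on a Shared Core

This account rests on a few compounds, and the source may have more. Where it says the series, first, only, none or still open, it means among the compounds named here.

Compound 2 `Clc1cccc(-c2nc(N3CCCCC3)c3nc[nH]c3n2)c1` was tested in an assay on cells for displacement of a labelled ligand from adenosine receptor A3 (Homo sapiens), read by scintillation counting and radioligand binding, with a stated time of 180 min, tested at 10 uM; a higher number here means more inhibition at the concentration tested (going by the name of the read-out), a lower number less inhibition. In this assay compound 2 gives > 80%, which is a limit of the assay rather than a number. Compound 1 `Clc1ccc(-c2nc(N3CCCCC3)c3nc[nH]c3n2)cc1` is measured in the same way. In this assay compound 1 gives > 80%, again a limit. Among the compounds with values here, the only measured step, a step that the two limits leave unreadable from compound 1 to compound 2, shows merely that both ends stand at the limit of > 80% in this assay, at which 2 of the 2 values shown sit, so its size cannot be read. Compound 3 `Oc1ccc(-c2nc(N3CCCCC3)c3nc[nH]c3n2)cc1` differs from compound 2 by 4-hydroxyphenyl in place of 3-chlorophenyl on an aromatic carbon. Within the data shown here, no measured step bears on this change, and the one step recorded sets no size in either direction. Since compound 2 itself sits at a limit, any estimate for compound 3 rests on a loosely anchored starting point. Compound 3 is therefore expected to give 55%, with a range from 20% to 85%. The estimated step of a number at least 25 percentage points lower from compound 2 to compound 3 (beyond the scatter) is expected to be a loss, but its size remains uncertain.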

Compound 3, a percentage reported as inhibition, at one concentration (the size of the read-out at that concentration, not a potency): > 80%
Compound 3: no number, only a limit; the forecaster's own chance of this, stated with the estimate: 35%; middle value at least 25 percentage points away from the limit.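

In this assay compound 3 gives > 80%, which is a limit. No size can be read for the steps from compound 1 or compound 2 to compound 3, because all three compounds stand at one limit: the limit of > 80% in this assay, at which 3 of the 3 values shown sit.

The compounds shown leave open how 3-chlorophenyl, 4-chlorophenyl and 4-hydroxyphenyl rank against one another in this assay.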